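Mirror-Image Hydrazone: Redrawn Double Bond, Same Cytotoxicity Expected

A few compounds are considered here, and "the series" means these few. Any claim that something is new, unique, unknown or untested is made for them only; others in the source may bear on it.

Three hydrazones built on one shared core have been measured. Compound 1 `NC(=S)N/N=C1\CCCc2cccnc21` gives -3.8% in a toxicity assay on the whole organism (P388 cells, strain CDF1) for cytotoxicity, with Mus musculus as the target, with stated times of 6 days and 24 h, at a dose of 5 mg/kg; on this read-out higher numbers stand for a weaker effect at the one dose given and lower numbers for a stronger effect. Going by the values given here, compound 2 `CNC(=S)N/N=C1\CCCc2cccnc21` gives -12% in that read-out, and the single change of a methyl in place of hydrogen on an amide-type nitrogen moves the number a number 8.2 percentage points lower from compound 1 to compound 2 (within the scatter). Compound 3 `C=CCNC(=S)N/N=C1/CCCc2cccnc21` gives 0% in this assay. Among the three numbers compound 3 stands at the top: compound 1 lies within the scatter of it, while compound 2 sits lower by an amount beyond the scatter.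

Compound 4 `C=CCNC(=S)N/N=C1\CCCc2cccnc21` is the next step. Compared with compound 3, (the two compounds have the same atoms and bonds and differ only in configuration as drawn: 1 of 1 stereo elements differ; a double bond is drawn Z in compound 3 and E in compound 4). Among the compounds with values here, no measured pair shows this kind of change, so no step here bears on it directly; the only step available, from compound 1 to compound 2, concerns a different change and itself stays within the scatter. With nothing gained or lost in atoms or bonds, the expected movement in this assay is none beyond the scatter, a step of no change at the digits printed from compound 3 to compound 4 (within the scatter). Compound 4 is therefore estimated to give 0% in this assay, within a range from -15% to 15%.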

Compound 4, a percentage reported as activity, at one dose (the size of the read-out at that dose, not a potency): -8.4%
The estimate for compound 4 lay 8.4 percentage points above the measured number; the range from low to high includes it.
By their numbers in this assay, from the lowest: compounds 2, 4, 1 and 3 (each within the scatter of the next, the first and the last beyond it).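

Going by these compounds alone, this pair gives the first reading of the double bond's configuration: in this assay, redrawing it from Z to E gives a number 8.4 percentage points lower from compound 3 to compound 4 (within the scatter), so at this one dose the two forms cannot be told apart. That reading concerns the configuration alone, with no other change mixed in: the fact that compounds 3 and 4 differ only in the configuration as drawn

Compound 4 also links the allyl group to the two smaller substituents with the double bond drawn the same way. Allyl in place of hydrogen on the amide-type nitrogen gives a number 4.6 percentage points lower from compound 1 to compound 4 (within the scatter), while vinyl in place of hydrogen on the saturated chain carbon gives a number 3.6 percentage points higher from compound 2 to compound 4 (within the scatter), so no step among hydrogen, methyl and allyl on this nitrogen leaves the scatter.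

On these data alone, only the allyl compounds appear here in both drawn forms, so it remains open whether the double bond's configuration would matter with hydrogen or methyl on this nitrogen. As far as these compounds go, it is also open whether a longer chain such as butyl, or a phenyl ring, on that nitrogen would give a step beyond the scatter.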